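A methyl group added to compound 1

The source may report more compounds than this note shows. Statements on the series, on what has been measured and on what is new or still open speak of the compounds shown alone.

Compound 1 `CC1(C)CCC(C)(C)c2cc(-c3ccc4cc(C(=O)O)ccc4c3)ccc21`: 31 nM
Compound 2 `Cc1cc2c(cc1-c1ccc3cc(C(=O)O)ccc3c1)C(C)(C)CCC2(C)C`: > 100 nM, a limit and not a number

Within the data shown here, in a functional assay on F9 cells (Mus musculus) (on this read-out lower numbers stand for an effect already at smaller amounts and higher numbers for an effect only at larger amounts of compound), compound 1 gives 31 nM, the only true number so far. Compound 3 `Cc1c(-c2ccc3c(c2)C(C)(C)CCC3(C)C)ccc2cc(C(=O)O)ccc12` differs from compound 1 by one change: methyl in place of hydrogen on an aromatic carbon. Among the measured compounds shown here, the only measured step of this kind, made elsewhere on the shared core, is an at least 3.2-fold higher number from compound 1 to compound 2 (0.50 log units; beyond the scatter). Resting on that single step, a move of similar size to a higher number is expected in this assay, and the estimated step is a 3.2-fold higher number from compound 1 to compound 3 (0.51 log units; beyond the scatter). For compound 3 the expected value is 100 nM, with an estimated range from 35 nM to 300 nM.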

Compound 3, concentration for half-maximal effect: > 5000 nM
Compound 3 ended at the assay's limit; the forecaster's own chance of this, stated with the estimate: 40%; middle value at least 50-fold (1.69 log units) away from the limit.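

In this assay, methyl in place of hydrogen on an aromatic carbon, here ortho to a large group, gives an at least 160-fold higher number from compound 1 to compound 3 (2.20 log units; beyond the scatter). A single added carbon at this place is thus enough for a large step, which the earlier limit alone could not establish. The value of compound 3 is a limit of the assay and not a number: the limit of > 5000 nM in this assay, at which 1 of the 3 values shown sits.

On these data alone, compound 2 and compound 3 both stand at limits, and how far the two methyl positions truly differ stays open. Also open, as far as these compounds go, is whether a fluorine atom or a hydroxyl group at this place would give a step of similar size.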